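A few compounds are considered here, and "the series" means these few. Any claim that something is new, unique, unknown or untested is made for them only; others in the source may bear on it.

Working notes on the series. All three measured compounds share one core and the trimethoxyphenylamino group. In a functional assay on MCF7 cells (Homo sapiens) for cytotoxicity, read by MTT assay, with a stated time of 72 h (a lower number here means a stronger inhibitor, a higher number a weaker inhibitor), compound 1 `CCOC(=O)c1sc2cccc(C)c2c1Nc1cc(OC)c(OC)c(OC)c1` gives 4150 nM, compound 2 `CCOC(=O)c1sc2ncccc2c1Nc1cc(OC)c(OC)c(OC)c1` gives 5280 nM, and compound 3 `COC(=O)c1sc2c(C)cccc2c1Nc1cc(OC)c(OC)c(OC)c1` gives 4550 nM. The number for compound 2 lies within the scatter of the number for compound 3 and of the number for compound 1, so the three compounds cannot be told apart on these data. Compound 4 `COC(=O)c1sc2ncccc2c1Nc1cc(OC)c(OC)c(OC)c1` is not yet measured. It differs from compound 2 by hydrogen in place of methyl on a saturated chain carbon bound to an oxygen next to a carbonyl group. For the measured compounds named here, no measured pair isolates this change, so no step beyond the scatter is expected, in either direction, and the estimate simply follows compound 2. Compound 4 is expected to give 5000 nM, between 2500 nM and 10000 nM, an expected step of a 1.1-fold lower number from compound 2 to compound 4 (0.02 log units; within the scatter).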

Compound 4, half-maximal inhibitory concentration: 2640 nM
The estimate for compound 4 lay 1.9-fold (0.28 log units) above the measured number, within the range that was stated.
By their numbers in this assay, from the lowest: compounds 4, 1, 3 and 2 (each within the scatter of the next).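

In this assay, for the compounds shown here, ethyl to methyl in the ethoxycarbonyl group gives a 2.0-fold lower number from compound 2 to compound 4 (0.30 log units; within the scatter), the first step that isolates a single place. This step is within the scatter, so compound 2 and compound 4 cannot be told apart, and these data show no effect of this change at this position. No measurement available here bears on the basis of this result.

Going by these compounds, whether a longer chain or a carboxylic acid here would give a step beyond the scatter remains open. Compound 1 and compound 3 differ in more than one place, so they offer no second reading of this change.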